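A few compounds are considered here, and "the series" means these few. Any claim that something is new, unique, unknown or untested is made for them only; others in the source may bear on it.

Compound 1 `N#CN/C(=N\C1CCCC1)Nc1cccnc1`: 20 mg/kg
Compound 2 `CCC(C)(CC)/N=C(\NC#N)Nc1cccnc1`: 0.5 mg/kg

Of these two, compound 2 holds the lowest number in a functional assay on the whole organism (blood, strain Wistar-Okamoto) with Rattus norvegicus as the target, with a stated time of 5 days (on this read-out higher numbers stand for an effect only at larger amounts of compound and lower numbers for an effect already at smaller amounts), so it acts already at the smaller amount. For the measured compounds named here, its only neighbour is compound 1, and the single measured step, a 40-fold lower number from compound 1 to compound 2 (1.60 log units; beyond the scatter), separates them; that step goes with 1-ethyl-1-methylpropyl in place of cyclopentyl on a double-bonded nitrogen.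

Compound 3 `CC1(/N=C(\NC#N)Nc2cccnc2)CCC1` has not yet been measured in this assay. It differs from compound 2 in one place: 1-methylcyclobutyl in place of 1-ethyl-1-methylpropyl on a double-bonded nitrogen. This change brings a ring back, as in compound 1, while keeping a methyl on the ring carbon that meets the double-bonded nitrogen, which neither compound 1 nor compound 2 alone shows. Going by the values given here, the measured step of a 40-fold lower number from compound 1 to compound 2 (1.60 log units; beyond the scatter) is the only guide, and it is large. A step toward a higher number is therefore expected for compound 3, though a smaller one than that step, since the new group shares features of both measured groups. Compound 3 is estimated at 2 mg/kg in this assay, in a range from 0.5 mg/kg to 8 mg/kg, which corresponds to the expected step of a 4.0-fold higher number from compound 2 to compound 3 (0.60 log units; beyond the scatter).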

Compound 3, minimum effective dose: 50 mg/kg
For compound 3 the middle estimate is 25-fold (1.40 log units) below the measured one; the whole stated range lies below it.
By their numbers in this assay, from the lowest: compound 2; then compound 1; then compound 3.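

In this assay, a ring bearing a methyl does not restore the low number of the open-chain group: 1-methylcyclobutyl in place of 1-ethyl-1-methylpropyl on the double-bonded nitrogen gives a 100-fold higher number from compound 2 to compound 3 (2.00 log units; beyond the scatter). Set against cyclopentyl, the same group gives only a 2.5-fold higher number from compound 1 to compound 3 (0.40 log units; beyond the scatter), a modest step beside that large one, so among these three compounds only the open-chain 1-ethyl-1-methylpropyl of compound 2 goes with an effect at a small dose. No accompanying data speak to the reason for these differences.

The compounds shown leave open whether the rise follows from the ring itself or from the change in size, since 1-methylcyclobutyl differs from 1-ethyl-1-methylpropyl in having a four-membered ring and also in its count of heavy atoms. As far as these compounds go, how a tert-butyl or a 1-methylcyclopentyl group on the same double-bonded nitrogen would read also remains open, and either could help to pull these two features apart.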